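A few compounds are considered here, and "the series" means these few. Any claim that something is new, unique, unknown or untested is made for them only; others in the source may bear on it.

Measured compounds in an assay on HEK293 cells for antagonist activity at Voltage-dependent L-type calcium channel subunit alpha-1C (Oryctolagus cuniculus), read by FLIPR; a lower number here means a stronger inhibitor, a higher number a weaker inhibitor:
compound 1, `COC(=O)C1=C(C)NC(=O)NC1c1cccc([N+](=O)[O-])c1`, gives 11700 nM
compound 2, `CC1=C(C(=O)OC(C)C)C(c2cccc([N+](=O)[O-])c2)NC(=O)N1`, gives 58100 nM
compound 3, `COC(=O)C1=C(C)OC(N)=C(C(=O)OC(C)C)C1c1cccc([N+](=O)[O-])c1`, gives 410 nM

Compound 1 and compound 2 share a core and differ in one place: isopropyl in place of methyl on an oxygen next to a carbonyl group. In this assay this change gives a 5.0-fold higher number from compound 1 to compound 2 (0.70 log units; beyond the scatter). Compound 3 stands on a different core; the difference between the core of compound 1 and the core of compound 3 is not broken down here. In this assay compound 3 gives the lowest number of the three, beyond the scatter from both compound 1 and compound 2.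

Compound 4, `CC1=C(C(=O)OC(C)C)C(c2cccc([N+](=O)[O-])c2)C(C(=O)OC(C)C)=C(N)O1`, is not yet measured. It differs from compound 3 in one place: isopropyl in place of methyl on an oxygen next to a carbonyl group. The place is described in the same words as for the change from compound 1 to compound 2, so this is the same change, now made on the core of compound 3. Within the data shown here, only one measured example of the change exists, and it sits on another core, so how far it carries over is open. Because the step of a 5.0-fold higher number from compound 1 to compound 2 (0.70 log units; beyond the scatter) is modest and beyond the scatter, a step of the same direction and roughly similar size is expected here, somewhat tempered for the change of core. For compound 4 the expected step in this assay is a 3.9-fold higher number from compound 3 to compound 4 (0.59 log units; beyond the scatter). Compound 4 is thus estimated at 1600 nM in this assay, with a range from 500 nM to 5000 nM.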

Compound 4, half-maximal inhibitory concentration: 860 nM
The estimate for compound 4 lay 1.9-fold (0.27 log units) above the measured number, and the stated range covers the measured number.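

In this assay, isopropyl in place of methyl on an oxygen next to a carbonyl group gives a 2.1-fold higher number from compound 3 to compound 4 (0.32 log units; beyond the scatter). The step runs in the same direction on both cores, and the two sizes cannot be told apart: the same change on two cores in this assay, a 5.0-fold higher number (0.70 log units; beyond the scatter) from compound 1 to compound 2 and a 2.1-fold higher number (0.32 log units; beyond the scatter) from compound 3 to compound 4, 2.4-fold (0.37 log units) apart, within the scatter of two such steps. Among these compounds, this supports carrying the change between these two cores in this assay, but it rests on only two matched pairs and does not show that the step would hold on any further core or explain why it occurs.

The compounds shown leave open what a longer chain, a benzyl group or a carboxylic acid would do in place of the methyl or isopropyl ester. From the compounds shown here alone, all of them also carry the nitro group, so the effect of a nitrile or a trifluoromethyl group in its place, and whether the ester step would stay the same with either, remains unknown.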